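The source may report more compounds than this note shows. Statements on the series, on what has been measured and on what is new or still open speak of the compounds shown alone.

Measured so far:
Compound 1, `COc1cc(-c2cc(/C=C/C(=O)c3ccc(N)cc3)[nH]n2)cc(OC)c1OC`: 2060 nM
Compound 2, `COc1cc(-c2cc(/C=C/C(=O)c3ccc(Cl)c(Cl)c3)[nH]n2)cc(OC)c1OC`: 8650 nM

Both compounds share the same core and were tested in a functional assay on MDA-MB-231 cells (Homo sapiens) for inhibition, read by sulforhodamine B assay, with a stated time of 48 h; on this read-out lower numbers stand for stronger inhibition of growth and higher numbers for weaker inhibition of growth. Compound 2 stands highest of the two numbers; its nearest neighbour is compound 1, and the step of a 4.2-fold higher number from compound 1 to compound 2 (0.62 log units; beyond the scatter) separates them, so compound 2 is the weaker growth inhibitor of the pair.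

Compound 3, `COc1ccc(C(=O)/C=C/c2cc(-c3cc(OC)c(OC)c(OC)c3)n[nH]2)cc1OC`, has not yet been measured in this assay. It differs from compound 2 in one place: 3,4-dimethoxyphenyl in place of 3,4-dichlorophenyl on a carbonyl carbon. Among the compounds with values here, the only measured step that bears on a change at this carbonyl carbon is a 4.2-fold higher number from compound 1 to compound 2 (0.62 log units; beyond the scatter), which shows that exchanging the group on that position can shift the number by a modest but real amount. Within the data shown here, no measured pair shows the dimethoxyphenyl group itself, so the direction of its effect is uncertain. With the dichlorophenyl group removed, compound 3 is expected to return part of the way toward the number of compound 1, giving an expected step of a 2.2-fold lower number from compound 2 to compound 3 (0.33 log units; beyond the scatter). Compound 3 is therefore estimated at 4000 nM in this assay, with a range from 1500 nM to 12000 nM.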

Compound 3, concentration for 50% growth inhibition: 1480 nM
Compound 3: the middle estimate sits 2.7-fold (0.43 log units) above what was measured; measured number outside the range, below it.
By their numbers in this assay, from the lowest: compounds 3 and 1 (each within the scatter of the next); then compound 2.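

Placing 3,4-dimethoxyphenyl on the carbonyl carbon in place of 3,4-dichlorophenyl gives a 5.8-fold lower number from compound 2 to compound 3 (0.77 log units; beyond the scatter) in this assay, so this exchange moves the number further than the one step known before, and in the opposite direction. Compared with 4-aminophenyl, the same group gives a 1.4-fold lower number from compound 1 to compound 3 (0.14 log units; within the scatter), which means these two different groups cannot be told apart on this read-out, and among the three compounds only the 3,4-dichlorophenyl group stands apart, with the weaker growth inhibition. The entering group carries 2 hydrogen-bond acceptors where 3,4-dichlorophenyl carries 0, but the compounds shown offer no independent measurement that could connect this count, or anything else, to the gap.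

Still open, as far as these compounds go, is whether a plain phenyl group, or a phenyl group with a single methoxy group, would sit with compound 1 and compound 3 or with compound 2. From the compounds shown here alone, all three compounds also keep the rest of the molecule unchanged, so it remains unknown whether these differences would hold if another part of the shared core were altered.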